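A few compounds are considered here, and "the series" means these few. Any claim that something is new, unique, unknown or untested is made for them only; others in the source may bear on it.

In an ADME assay on CHO cells (Cricetulus griseus) for cytotoxicity, read by MTT assay, with a stated time of 68 h (on this read-out lower numbers stand for stronger inhibition and higher numbers for weaker inhibition), the measured compounds stand as follows:

compound 1 `O=C(/C=C/c1cccc(OCc2ccccc2)c1)c1ccc([N+](=O)[O-])cc1` at 82400 nM
compound 2 `O=C(/C=C/c1cccc(OCc2ccccc2)c1)c1ccc(Cl)cc1` at 43600 nM
compound 3 `Cc1ccc(C(=O)/C=C/c2cccc(OCc3ccccc3)c2)cc1` at 26400 nM

Compound 2 holds the middle place among these three numbers, and neither of its measured neighbours stands clear of it (a 1.9-fold lower number from compound 1 to compound 2 (0.28 log units; within the scatter)) (a 1.7-fold lower number from compound 2 to compound 3 (0.22 log units; within the scatter)). The next compound, compound 4 `O=C(/C=C/c1cccc(OCc2ccccc2)c1)c1ccccc1`, differs from compound 2 by hydrogen in place of chloro on an aromatic carbon (hydrogen in place of chloro on an aromatic carbon, para to a large group). For the measured compounds named here, no measured compound carries hydrogen at this place, so the evidence is indirect. It comes from the exchanges of one group for another at the same place: the two steps just given and the largest of the set, which is modest (a 3.1-fold lower number from compound 1 to compound 3 (0.49 log units; beyond the scatter)). Changes here have therefore moved the number in this assay only a little. No step beyond the scatter is expected for hydrogen, and neither direction is favoured. The expected step is small (a 1.1-fold lower number from compound 2 to compound 4 (0.04 log units; within the scatter)). For compound 4 the expected value is 40000 nM (estimated range 18000 nM to 85000 nM).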

Compound 4, half-maximal inhibitory concentration: 22000 nM
Estimate against measurement, compound 4: 1.8-fold (0.26 log units) above; the measured number falls inside the stated range.
By their numbers in this assay, from the lowest: compounds 4, 3, 2 and 1 (each within the scatter of the next, the first and the last beyond it).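

In this assay, hydrogen at this place, para to a large group, gives a number that cannot be told apart from those of the chloro compound (a 2.0-fold lower number from compound 2 to compound 4 (0.30 log units; within the scatter)) or the methyl compound (a 1.2-fold lower number from compound 3 to compound 4 (0.08 log units; within the scatter)), so neither group is shown to matter here. Only the nitro compound stands clear of the hydrogen compound, by the largest step now seen at this place, which is still modest (a 3.7-fold lower number from compound 1 to compound 4 (0.57 log units; beyond the scatter)). Compound 2 goes against a clean split of nitro from the rest, as it remains within the scatter of compound 1.

As far as these compounds go, whether an amine or a carboxylic acid at this place would move the number further stays open. Nothing shown here bears on why the numbers fall as they do.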